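Replacing 5-chloro-1-benzothiophen-3-yl with 4-methoxyphenyl

The compounds below may be only part of what the source reports. "The series", "measured", "known", "first", "only" and "open" are said of these compounds alone.

Measured so far in a functional assay on MCF7 cells (Homo sapiens) for inhibition, read by MTT assay, with a stated time of 72 h; a higher number here means a weaker inhibitor, a lower number a stronger inhibitor:
- Compound 1 `Cc1cc(Nc2ccn(Cc3cccc4ccccc34)n2)n2nc(SCc3ccc(Br)cc3)nc2n1`: 4310 nM
- Compound 2 `Cc1cc(Nc2ccn(Cc3csc4ccc(Cl)cc34)n2)n2nc(SCc3ccc(Br)cc3)nc2n1`: 2570 nM

Going by the values given here, compound 2 stands level with compound 1 on these numbers, because the only measured step between them is a 1.7-fold lower number from compound 1 to compound 2 (0.22 log units; within the scatter) and so neither can be called the better of the two.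

Compound 3 `COc1ccc(Cn2ccc(Nc3cc(C)nc4nc(SCc5ccc(Br)cc5)nn34)n2)cc1` keeps the shared core and changes one group: 4-methoxyphenyl in place of 5-chloro-1-benzothiophen-3-yl on a saturated chain carbon bound to an aromatic nitrogen. Here 4-methoxyphenyl stands in place of 5-chloro-1-benzothiophen-3-yl on a saturated chain carbon bound to an aromatic nitrogen.

The measured step at this same place is the one already given, where 5-chloro-1-benzothiophen-3-yl replaced naphthalen-1-yl and the number stayed within the scatter. Among the compounds with values here, it says little about 4-methoxyphenyl, which no measured compound carries. A similarly small change is therefore the best guess, with a weak lean toward a higher number. The expected step is a 1.5-fold higher number from compound 2 to compound 3 (0.17 log units; within the scatter) but a larger one in either direction remains possible. For compound 3 the estimated value is 3800 nM, with an expected range from 1500 nM to 10000 nM.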

Compound 3, half-maximal inhibitory concentration: 14600 nM
For compound 3 the middle estimate is 3.8-fold (0.58 log units) below the measured one; measured number above the stated range.
By their numbers in this assay, from the lowest: compounds 2 and 1 (each within the scatter of the next); then compound 3.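

In this assay, going by these compounds alone, the group on the saturated chain carbon bound to an aromatic nitrogen now clearly matters: putting 4-methoxyphenyl in place of 5-chloro-1-benzothiophen-3-yl gives a 5.7-fold higher number from compound 2 to compound 3 (0.75 log units; beyond the scatter) and is the first step in this set that lies beyond the scatter. Set against naphthalen-1-yl, the same group gives a 3.4-fold higher number from compound 1 to compound 3 (0.53 log units; beyond the scatter) and so the 4-methoxyphenyl compound is the weaker inhibitor in both comparisons, while the other two groups still cannot be told apart. No measurement offered here explains this loss, which therefore stands as an observation without a known cause.

On these data alone, whether the loss follows from the methoxy group itself or from having one aromatic ring rather than a larger ring system stays open, and plain phenyl or 4-chlorophenyl at this position would help to separate the two. As far as these compounds go, how a saturated ring such as cyclohexyl, or a chain ending in an amine, would behave here also remains unknown.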